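Extending a dimethylcarbamoyl group by one methyl

The source may report more compounds than this note shows. Statements on the series, on what has been measured and on what is new or still open speak of the compounds shown alone.

Compound 1 (`Cc1cnc(NC(=O)c2cc(Oc3cnc(C(=O)N(C)C)cn3)c3cc(C)oc3c2)cn1`) is followed here in an ADME assay (liver) for metabolic stability, with Liver microsome (Homo sapiens) as the target, using microsomes; on this read-out lower numbers stand for slow clearance and higher numbers for fast clearance. Compound 1 gives < 8.5 mL/min/kg, which is a limit of the assay and not a number. Compound 3 (`Cc1cnc(NC(=O)c2cc(Oc3ncc(C(=O)N(C)C)cn3)c3cc(C)oc3c2)cn1`) gives < 8 mL/min/kg, which is also a limit and not a number. Compound 2 (`Cc1cnc(NC(=O)c2cc(Oc3ccc(C(=O)N(C)C)cc3)c3cc(C)oc3c2)cn1`) is the only one of the three with a measured number, at 17 mL/min/kg. Compound 1 therefore stands with compound 3 at the limits of this assay, and neither can be ranked exactly against the other.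

The next compound, compound 4 (`CCN(C)C(=O)c1cnc(Oc2cc(C(=O)Nc3cnc(C)cn3)cc3oc(C)cc23)cn1`), keeps the core of compound 1 and changes only its amide: methyl in place of hydrogen on a saturated chain carbon bound to an amide-type nitrogen. A methyl takes the place of a hydrogen on a saturated chain carbon bound to an amide-type nitrogen, turning dimethylcarbamoyl into ethyl(methyl)carbamoyl. Going by the values given here, no measured pair in this small set isolates such a change, so the expectation rests on the limit of compound 1 and on the number of compound 2 as a measured reference. The estimated step of an at least 1.1-fold higher number from compound 1 to compound 4 (0.07 log units; that floor lies within the scatter) is expected to lean slightly upward, with nothing beyond the scatter. Compound 4 is expected at 10 mL/min/kg, within an estimated range from 6 mL/min/kg to 18 mL/min/kg.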

Compound 4, clearance: < 8 mL/min/kg
Compound 4: a limit, no number; the forecaster's own chance of this, stated with the estimate: 45%; at least 1.2-fold (0.09 log units) between middle value and limit.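

In this assay compound 4 gives < 8 mL/min/kg, which is a limit of the assay and not a number. Going by these compounds alone, compound 1 also stands at a limit, so no step from compound 1 to compound 4 can be read. The compounds shown leave open whether going from dimethylcarbamoyl to ethyl(methyl)carbamoyl changes the clearance at all.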